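The compounds below may be only part of what the source reports. "The series", "measured", "known", "first", "only" and "open" are said of these compounds alone.

Compound 2, with the structure `CCCCCCCCN(C)C(=O)Cn1cc(Cc2cnc(=O)n(CC(=O)N3CCN(C)CC3)c2)c(=O)nc1SCc1ccc(F)cc1`, is the starting point. In a functional assay on a cell-free system (plasma, Oryctolagus cuniculus) for inhibition of platelet-activating factor acetylhydrolase (Homo sapiens), tested at 100 nM (on this read-out lower numbers stand for less inhibition and higher numbers for more inhibition at the one concentration tested (going by the name of the read-out)), compound 2 gives 40%. For the measured compounds named here, the only other measured compound, compound 1, with the structure `CCCCCCCCN(C)C(=O)Cn1cc(Cc2cnc(=O)n(CC(=O)NCCO)c2)c(=O)nc1SCc1ccc(F)cc1`, gives 40% in this assay, so compound 2 stands level with compound 1 within the scatter of the measurement. Going by the values given here, the one measured step, no change at the digits printed from compound 1 to compound 2 (within the scatter), exchanged the group on the same carbonyl carbon that is altered here.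

Compound 3, with the structure `CCCCCCCCN(C)C(=O)Cn1cc(Cc2cnc(=O)n(CC(=O)N3CCNC(=O)C3)c2)c(=O)nc1SCc1ccc(F)cc1`, has not been measured. It differs from compound 2 in one place: 3-oxopiperazin-1-yl in place of 4-methylpiperazin-1-yl on a carbonyl carbon. Among the compounds with values here, since the single known exchange at this carbonyl carbon left the inhibition unchanged within the scatter, the expectation for this further exchange at the same carbon is a step of no change at the digits printed from compound 2 to compound 3 (within the scatter), that is, no change beyond the scatter. Compound 3 is therefore estimated to give 40% in this assay, within a range from 25% to 55%.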

Compound 3, a percentage reported as inhibition, at one concentration (the size of the read-out at that concentration, not a potency): 55%
The estimate for compound 3 lay 15 percentage points below the measured number; the measured number falls inside the stated range.
By their numbers in this assay, from the lowest: compounds 1 and 2 (each within the scatter of the next); then compound 3.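

In this assay, this carbonyl carbon no longer looks indifferent to its group: the exchange to 3-oxopiperazin-1-yl gives a number 15 percentage points higher from compound 2 to compound 3 (beyond the scatter), and the same group in place of (2-hydroxyethyl)amino gives a number 15 percentage points higher from compound 1 to compound 3 (beyond the scatter). For the compounds shown here, both steps are modest, but they show that the group here can move the number, which the one earlier exchange did not. The leaving and entering rings are both six-membered and have the same heavy-atom count, so a change within the ring, with its size kept, is enough to produce a step beyond the scatter. Nothing available explains the rise.

From the compounds shown here alone, it remains open whether the oxo group or the hydrogen-bond donor in the ring goes with the higher number. An unsubstituted piperazin-1-yl or a morpholin-4-yl on the same carbonyl carbon could help separate the two.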